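Replacing the hydroxyquinolinyl arm of compound 3 with phenyl

The source may report more compounds than this note shows. Statements on the series, on what has been measured and on what is new or still open speak of the compounds shown alone.

Of the compounds shown here, three built on one shared core have been measured in a functional assay on HeLa cells (Homo sapiens) for cytotoxicity, read by MTT assay, with a stated time of 48 h; on this read-out lower numbers stand for stronger inhibition and higher numbers for weaker inhibition. Compound 1 `Cc1nc2c3ccccc3ccc2c2nc3c(ccc4ccccc43)c(-c3cccc([N+](=O)[O-])c3)c12` gives 50700 nM. Compound 2 `Cc1nc2c3ccccc3ccc2c2nc3c(ccc4ccccc43)c(-c3cccnc3)c12` gives 3860 nM, and compound 3 `Cc1nc2c3ccccc3ccc2c2nc3c(ccc4ccccc43)c(-c3cc(O)nc4ccccc34)c12` gives 4880 nM. Within the data shown here, of these three numbers the one for compound 3 is the second highest; its nearest neighbour is compound 2, and that pair sits within the scatter, while compound 1 lies furthest from it. The step of a 10-fold lower number from compound 1 to compound 3 (1.02 log units; beyond the scatter) is large, as is a 13-fold lower number from compound 1 to compound 2 (1.12 log units; beyond the scatter), whereas a 1.3-fold higher number from compound 2 to compound 3 (0.10 log units; within the scatter) stays within the scatter.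

Compound 4 `Cc1nc2c3ccccc3ccc2c2nc3c(ccc4ccccc43)c(-c3ccccc3)c12` has not yet been measured in this assay. It differs from compound 3 in a single place: phenyl in place of 2-hydroxyquinolin-4-yl on an aromatic carbon. Among the measured compounds shown here, none of the measured steps concerns a plain phenyl at that position. What the steps show is only that a 3-nitrophenyl there stands far apart from both pyridin-3-yl and 2-hydroxyquinolin-4-yl, which themselves sit together. The account therefore expects for compound 4 a step of a 1.6-fold higher number from compound 3 to compound 4 (0.21 log units; within the scatter), a modest rise that may well remain within the scatter. Compound 4 is estimated at 8000 nM, with a range from 2500 nM to 30000 nM.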

Compound 4, half-maximal inhibitory concentration: > 80000 nM
Compound 4: no number, only a limit (the forecaster's own chance of this, stated with the estimate: 5%); at least 10-fold (1.00 log units) between middle value and limit.
By their numbers in this assay, from the lowest: compounds 2 and 3 (each within the scatter of the next); then compound 1. At a limit, above all of these: compound 4.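

In this assay compound 4 gives no number, only a limit: the limit of > 80000 nM in this assay, at which 1 of the 4 values shown sits.

Even so, the steps of an at least 16-fold higher number from compound 3 to compound 4 (1.21 log units; beyond the scatter) and an at least 20-fold higher number from compound 2 to compound 4 (1.31 log units; beyond the scatter) are both large, so this position does not treat all aromatic arms alike, as the earlier compounds could not show, and a plain phenyl on this aromatic carbon does not stand with pyridin-3-yl or 2-hydroxyquinolin-4-yl. The difference between phenyl and pyridin-3-yl is a single ring atom, and the step of an at least 1.5-fold higher number from compound 1 to compound 4 (0.19 log units; that floor lies within the scatter), whose floor lies within the scatter, shows no sign that taking away the nitro group brings the number down towards those two compounds, so the high number of the 3-nitrophenyl compound now looks less like a penalty from nitro alone.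

From the compounds shown here alone, how far compound 4 truly lies beyond compound 1 stays open, since the limit gives only a floor, and so does the question of whether the nitro group changes the number at all. Also open, going by these compounds, is whether a phenyl carrying an amine or a hydroxyl group, or a pyridin-4-yl arm with its ring nitrogen elsewhere, would stand with compound 2 and compound 3 or with compound 4.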